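Chalcone series: a third methoxy on the aryl ring

A few compounds are considered here, and "the series" means these few. Any claim that something is new, unique, unknown or untested is made for them only; others in the source may bear on it.

Compound 1 `COc1ccc(C(=O)/C=C/c2cc(-c3cc(OC)c(OC)c(OC)c3)n3nc(-c4ccccc4)cc3n2)cc1` gives 13200 nM in a functional assay on MDA-MB-231 cells (Homo sapiens) for antiproliferative activity, read by MTT assay, with a stated time of 24 h; a higher number here means a weaker inhibitor, a lower number a stronger inhibitor.
Compound 2 `COc1cc(C(=O)/C=C/c2cc(-c3cc(OC)c(OC)c(OC)c3)n3nc(-c4ccccc4)cc3n2)cc(OC)c1OC` gives 24300 nM in this assay.
Compound 3 `COc1ccc(-c2cc(/C=C/C(=O)c3ccc(C)cc3)nc3cc(-c4ccccc4)nn23)cc1OC` gives 19800 nM in this assay.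

Compound 3 stands second highest of the three numbers; its nearest neighbour is compound 2 and its furthest is compound 1, both within the scatter, so no order among the three can be read. Compound 4 `COc1cc(-c2cc(/C=C/C(=O)c3ccc(C)cc3)nc3cc(-c4ccccc4)nn23)cc(OC)c1OC` differs from compound 3 by methoxy in place of hydrogen on an aromatic carbon, which read one bond further out is 3,4-dimethoxyphenyl to 3,4,5-trimethoxyphenyl. Among the compounds with values here, the only measured step, a 1.8-fold higher number from compound 1 to compound 2 (0.27 log units; within the scatter), enlarges the aryl group on the carbonyl carbon rather than this ring, so it bears only loosely on the change, and it stayed within the scatter. No step beyond the scatter is therefore expected in this assay, a 1.1-fold higher number from compound 3 to compound 4 (0.05 log units; within the scatter). Compound 4 is estimated at 22000 nM, with a range from 9000 nM to 55000 nM.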

Compound 4, half-maximal inhibitory concentration: 23900 nM
Compound 4: the middle estimate sits 1.1-fold (0.04 log units) below what was measured; measured number inside the range.
By their numbers in this assay, from the lowest: compounds 1, 3, 4 and 2 (each within the scatter of the next).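

In this assay, the change from 3,4-dimethoxyphenyl to 3,4,5-trimethoxyphenyl on the shared core, methoxy in place of hydrogen on an aromatic carbon, gives no readable shift (a 1.2-fold higher number from compound 3 to compound 4 (0.08 log units; within the scatter)). With that ring held as 3,4,5-trimethoxyphenyl, the group on the carbonyl carbon also gives no readable shift, whether 4-methylphenyl replaces 3,4,5-trimethoxyphenyl (a 1.0-fold lower number from compound 2 to compound 4 (0.01 log units; within the scatter)) or methyl replaces methoxy (a 1.8-fold higher number from compound 1 to compound 4 (0.26 log units; within the scatter)).

An amine or a carboxylic acid at this ring position remains an open test of whether the number can move beyond the scatter. Nothing available explains these results.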